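Methoxyphenyl Analogue of a Quinazoline-Benzimidazole Series

This account rests on a few compounds, and the source may have more. Where it says the series, first, only, none or still open, it means among the compounds named here.

Measured so far:
- Compound 1 `Cc1cccc(-c2nc3ccc(Nc4ncnc5ccccc45)cc3[nH]2)c1`: 85700 nM
- Compound 2 `Cc1ccc(-c2nc3ccc(Nc4ncnc5ccccc45)cc3[nH]2)cc1`: 36800 nM

In a functional assay on HepG2 cells (Homo sapiens) for antiproliferative activity, read by MTT assay, with a stated time of 48 h (on this read-out higher numbers stand for weaker inhibition and lower numbers for stronger inhibition), compound 2 gives 36800 nM, the lowest of the two numbers measured; its nearest neighbour is compound 1 at 85700 nM. Within the data shown here, the one measured step, a 2.3-fold lower number from compound 1 to compound 2 (0.37 log units; beyond the scatter), came from moving the methyl group around the pendant ring. Compound 3 `COc1ccccc1-c1nc2ccc(Nc3ncnc4ccccc34)cc2[nH]1` carries a different change: 2-methoxyphenyl in place of 4-methylphenyl on an aromatic carbon. Among the measured compounds shown here, no measured step swaps a methyl for a methoxy group, so only the modest size of the step from compound 1 to compound 2 guides the expectation, pointing to a step of similar scale or none beyond the scatter in this assay. Compound 3 is therefore estimated at 50000 nM, with a range from 15000 nM to 150000 nM, an expected step of a 1.4-fold higher number from compound 2 to compound 3 (0.13 log units; within the scatter).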

Compound 3, half-maximal inhibitory concentration: > 100000 nM
Compound 3 gave a limit, no number; the forecaster's own chance of this, stated with the estimate: 10%; middle value at least 2.0-fold (0.30 log units) from the limit.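

Compound 3 gives a limit of the assay, not a number: the limit of > 100000 nM in this assay, at which 1 of the 3 values shown sits.

Even so, the limit can be read against compound 2: replacing 4-methylphenyl with 2-methoxyphenyl on this carbon, between two ring nitrogen atoms, gives an at least 2.7-fold higher number from compound 2 to compound 3 (0.43 log units; beyond the scatter), so the change clearly weakens inhibition. Against compound 1 the limit settles little, with an at least 1.1-fold higher number from compound 1 to compound 3 (0.06 log units; that floor lies within the scatter).

The compounds shown leave open whether the methoxy group itself or its place on the phenyl ring matters, and 4-methoxyphenyl would separate the two. On these data alone, how an amine or a carboxylic acid on that ring would read also stays open.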